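Halogen swap at the aromatic carbon of compound 3

A few compounds are considered here, and "the series" means these few. Any claim that something is new, unique, unknown or untested is made for them only; others in the source may bear on it.

Compound 3 `[N-]=[N+]=N[C@@H]1C(n2cc(Br)c(=O)[nH]c2=O)[Se][C@H](CO)[C@H]1O` is one of three analogues tested in a functional assay on HCT-116 cells (Homo sapiens) for cytotoxicity, read by sulforhodamine B assay; on this read-out lower numbers stand for stronger inhibition and higher numbers for weaker inhibition. In this assay compound 3 gives > 100000 nM, which is a limit of the assay and not a number. Compound 1 `Cc1cn(C2[Se][C@H](CO)[C@@H](O)[C@@H]2N=[N+]=[N-])c(=O)[nH]c1=O` gives > 100000 nM in this assay, also a limit. Compound 2 `[N-]=[N+]=N[C@@H]1C(n2cc(Cl)c(=O)[nH]c2=O)[Se][C@H](CO)[C@H]1O` gives > 100000 nM in this assay, again a limit. All three values sit at the limit of > 100000 nM in this assay, at which 3 of the 3 values shown sit. The steps a step that the two limits leave unreadable from compound 1 to compound 2, a step that the two limits leave unreadable from compound 1 to compound 3 and a step that the two limits leave unreadable from compound 2 to compound 3 therefore cannot be sized. Compound 4 `[N-]=[N+]=N[C@@H]1C(n2cc(I)c(=O)[nH]c2=O)[Se][C@H](CO)[C@H]1O` carries the change (iodo in place of bromo on an aromatic carbon). Going by the values given here, no measured step gives a readable size for this swap, so no direction can be taken from them. The expected step is a step that the limit leaves unreadable from compound 3 to compound 4, none beyond the scatter. Compound 4 is expected to give 150000 nM, between 50000 nM and 500000 nM, most likely again only as a limit.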

Compound 4, half-maximal inhibitory concentration: > 100000 nM
Compound 4: a limit, no number (the forecaster's own chance of this, stated with the estimate: 85%); the middle value lies beyond the limit too.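

Compound 4, like compound 1, compound 2 and compound 3, gives only a limit in this assay, so no step among them can be read: the limit of > 100000 nM in this assay, at which 4 of the 4 values shown sit.

The compounds shown leave open whether methyl, chloro, bromo and iodo differ at all in this assay.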